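From trifluoromethyl to methyl on a shared core

The source may hold more compounds than are shown below. What is called first, only, known or untested is meant among the compounds shown, and "the series" means these compounds.

Going by the values given here, in an ADME assay on the whole organism for pharmacokinetics, with Rattus norvegicus as the target, with a stated time of 6 h, at a dose of 10 mg/kg by the oral route (a higher number here means more compound in the circulation at the dose given, a lower number less compound in the circulation), compound 1 (`CC[C@H]1CN(c2ncc(C(=O)NC)nc2C(F)(F)F)CCN1C1CCN(C(=O)c2ccc(Cl)nc2N)CC1`) gives 3550 ng.h/mL and compound 2 (`CC[C@H]1CN(c2ncc(C(=O)NC3CC3)nc2C(F)(F)F)CCN1C1CCN(C(=O)c2ccc(Cl)nc2N)CC1`) gives 2090 ng.h/mL, so compound 2 stands within the scatter of the only other measured compound. Compound 3 (`CC[C@H]1CN(c2ncc(C(=O)NC3CC3)nc2C)CCN1C1CCN(C(=O)c2ccc(Cl)nc2N)CC1`) differs from compound 2 in one group: methyl in place of trifluoromethyl on an aromatic carbon. Among the compounds with values here, the sole measured step, a 1.7-fold lower number from compound 1 to compound 2 (0.23 log units; within the scatter), concerns cyclopropyl in place of methyl on an amide-type nitrogen. That is a different change at a different place, so it bears on this one only as a sign of how far such a single change has moved the number. Within the data shown here, no measured pair tests methyl in place of trifluoromethyl on an aromatic carbon. No step beyond the scatter is therefore expected in this assay, and no direction is favoured. The estimate amounts to an expected 1.1-fold lower number from compound 2 to compound 3 (0.04 log units; within the scatter). For compound 3 the estimated value is 1900 ng.h/mL, with an expected range from 650 ng.h/mL to 5500 ng.h/mL.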

Compound 3, area under the concentration-time curve: 11600 ng.h/mL
Estimate against measurement, compound 3: 6.1-fold (0.79 log units) below; the whole stated range lies below it.
By their numbers in this assay, from the lowest: compounds 2 and 1 (each within the scatter of the next); then compound 3.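

Methyl in place of trifluoromethyl, on an aromatic carbon next to the ring nitrogen, gives a 5.6-fold higher number from compound 2 to compound 3 (0.74 log units; beyond the scatter) in this assay. The earlier step at the amide-type nitrogen, a 1.7-fold lower number from compound 1 to compound 2 (0.23 log units; within the scatter), did not leave the scatter, so this position is the only place among the compounds shown where a single change has clearly moved the area under the concentration-time curve. Nothing available explains why the number rises with this replacement.

With only one replacement shown at this position, it remains open whether a hydrogen, a chlorine, an ethyl or a methoxy group there would give a number close to that of compound 3. As far as these compounds go, it is also open whether methyl in place of trifluoromethyl would produce a similar step when the amide carries the methyl group of compound 1 rather than cyclopropyl.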